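The compounds below may be only part of what the source reports. "The series", "measured", "known", "first", "only" and "open" are said of these compounds alone.

Series notes. Compound 1 `CCn1c(NC(C)(C)C)nc2ccsc2c1=O`, compound 2 `CCNc1nc2ccsc2c(=O)n1CC` and compound 3 `CCn1c(NC2CCOCC2)nc2ccsc2c1=O` share one core and differ only in the group on a nitrogen on an aromatic ring. In an assay on cells for inhibition of high affinity 3',5'-cyclic-AMP phosphodiesterase 7A (Homo sapiens), read by scintillation counting and cAMP accumulation, with a stated time of 30 min (a higher number here means a weaker inhibitor, a lower number a stronger inhibitor), compound 1 gives 1500 nM, compound 2 gives 2900 nM and compound 3 gives 430 nM. The step of a 1.9-fold higher number from compound 1 to compound 2 (0.29 log units; within the scatter) stays within the scatter, whereas a 3.5-fold lower number from compound 1 to compound 3 (0.54 log units; beyond the scatter) and a 6.7-fold lower number from compound 2 to compound 3 (0.83 log units; beyond the scatter) both go beyond it, so compound 3 stands at the lowest number of the three measured.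

Compound 4 `CCn1c(NC2CCC2)nc2ccsc2c1=O` continues from compound 3 with the change (cyclobutyl in place of oxan-4-yl on a nitrogen on an aromatic ring). The steps from compound 1 and from compound 2 to compound 3 bear on it: both showed that the oxan-4-yl group gave a lower number than either tert-butyl or ethyl. Taking the oxan-4-yl away again is therefore expected to move the number back toward those of compound 1 and compound 2, and the expected step of a 2.3-fold higher number from compound 3 to compound 4 (0.37 log units; beyond the scatter) is a modest rise in this assay. Compound 4 is estimated at 1000 nM, with a range from 400 nM to 2500 nM.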

Compound 4, half-maximal inhibitory concentration: 300 nM
For compound 4 the middle estimate is 3.3-fold (0.52 log units) above the measured one, and the stated range ends above it.
By their numbers in this assay, from the lowest: compounds 4 and 3 (each within the scatter of the next); then compounds 1 and 2 (each within the scatter of the next).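

Cyclobutyl in place of oxan-4-yl on this nitrogen gives a 1.4-fold lower number from compound 3 to compound 4 (0.16 log units; within the scatter) in this assay, so the ring oxygen can be lost, along with its hydrogen-bond acceptor, with no change beyond the scatter. The advantage over the open-chain groups therefore does not belong to oxan-4-yl alone, as cyclobutyl also shows a 9.7-fold lower number from compound 2 to compound 4 (0.99 log units; beyond the scatter) and a 5.0-fold lower number from compound 1 to compound 4 (0.70 log units; beyond the scatter); among these four compounds, both ring-bearing compounds give lower numbers than ethyl and tert-butyl, and none goes against this. What lies behind this difference cannot be said, as no supporting evidence is available.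

The compounds shown leave open how cyclopentyl or cyclohexyl would read on this nitrogen. Also open, from the compounds shown here alone, is whether a ring amine such as piperidin-4-yl would fit the same trend.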